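Replacing methyl with a difluorophenyl ring on the oxadiazole

The source may hold more compounds than are shown below. What is called first, only, known or untested is meant among the compounds shown, and "the series" means these compounds.

Compound 1 `CC(C)(C)n1ncc(OCc2nnc(-c3ccc(Cl)cc3Cl)s2)c(Cl)c1=O`: 62.2 ug/mL
Compound 2 `COc1c(F)c(F)cc(-c2nnc(COc3cnn(C(C)(C)C)c(=O)c3Cl)o2)c1F`: > 300 ug/mL
Compound 3 `Cc1nnc(COc2cnn(C(C)(C)C)c(=O)c2Cl)o1`: > 300 ug/mL

Of the compounds shown here, three sharing the same core have been tested in a functional assay on the whole organism for inhibition, with Mythimna separata as the target, with a stated time of 5 days; a lower number here means that less compound is needed, a higher number that more compound is needed for the effect. Compound 1 gives 62.2 ug/mL. Compound 2 reaches only the limit of the assay, > 300 ug/mL, not a number. On these data alone, compound 3 likewise sits at the limit, > 300 ug/mL; it stands at the limit of > 300 ug/mL in this assay, at which 2 of the 3 values shown sit, so its true value is unknown beyond that bound.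

Compound 4 `CC(C)(C)n1ncc(OCc2nnc(-c3c(F)cccc3F)o2)c(Cl)c1=O` differs from compound 3 by 2,6-difluorophenyl in place of methyl on an aromatic carbon. Going by the values given here, no measured pair isolates this change. Compound 1 and compound 2 both carry a substituted phenyl ring at that place, yet one gives a number and the other a limit, so the outcome is uncertain. Compound 4 is expected to give about 200 ug/mL, within 60 ug/mL to 600 ug/mL, an estimated step of an at least 1.5-fold lower number from compound 3 to compound 4 (0.17 log units; that floor lies within the scatter) that may remain hidden by the limit.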

Compound 4, half-maximal effective concentration: 45.4 ug/mL
For compound 4 the middle estimate is 4.4-fold (0.64 log units) above the measured one; measured number outside the range, below it.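

In this assay, going by these compounds alone, 2,6-difluorophenyl in place of methyl on this aromatic carbon gives an at least 6.6-fold lower number from compound 3 to compound 4 (0.82 log units; beyond the scatter), the first single-change pair at this position, and it shows that an aromatic ring here can bring a measurable value. Compound 3 has only a limit, so the true step may be larger: the limit of > 300 ug/mL in this assay, at which 2 of the 4 values shown sit. Compound 2 goes against any simple rule: it also carries a substituted phenyl ring here, yet gives only a limit, > 300 ug/mL.

On these data alone, whether the fluorines matter stays open. So does how plain phenyl, cyclohexyl or an amine at this position would compare.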